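Moving the Ethyl Group on the Benzyl Ring

This account rests on a few compounds, and the source may have more. Where it says the series, first, only, none or still open, it means among the compounds named here.

Compound 1 `CCc1cccc(CC(C)(Oc2ccc(C(C)C)cc2)C(=O)O)c1` is tested in a functional assay on the whole organism for inhibition, with Rattus norvegicus as the target (a higher number here means that more compound is needed for the effect, a lower number that less compound is needed), where compound 1 gives 0.5 mg/kg. Compound 2 `CCc1ccc(CC(C)(Oc2ccc(C(C)C)cc2)C(=O)O)cc1` differs from it by 4-ethylphenyl in place of 3-ethylphenyl on a saturated chain carbon, two bonds along the chain from a carbonyl carbon and an oxygen on an aromatic ring; in this assay compound 2 gives 0.1 mg/kg, a step of a 5.0-fold lower number from compound 1 to compound 2 (0.70 log units; beyond the scatter). Compound 3 `CCc1cccc(CC(C)(Oc2ccc(Cc3ccccc3)cc2)C(=O)O)c1` is built on a different core, and in this assay compound 3 gives 0.1 mg/kg, which is a 5.0-fold lower number from compound 1 to compound 3 (0.70 log units; beyond the scatter). Compound 4 `CCc1ccc(CC(C)(Oc2ccc(Cc3ccccc3)cc2)C(=O)O)cc1` has not been measured. It differs from compound 3 by 4-ethylphenyl in place of 3-ethylphenyl on a saturated chain carbon, two bonds along the chain from a carbonyl carbon and an oxygen on an aromatic ring, the same change that was made from compound 1 to compound 2, here on a core that differs from that of compound 1 by benzyl in place of isopropyl on an aromatic carbon. A step of similar size is expected for compound 4, namely a 3.3-fold lower number from compound 3 to compound 4 (0.52 log units; beyond the scatter), because compound 1 to compound 2 gave a 5.0-fold lower number from compound 1 to compound 2 (0.70 log units; beyond the scatter). In this assay compound 4 is therefore expected at about 0.03 mg/kg, estimated between 0.01 mg/kg and 0.1 mg/kg.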

Compound 4, dose for half-maximal effect: 1 mg/kg
Compound 4: the middle estimate sits 33-fold (1.52 log units) below what was measured, and the stated range ends below it.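

In this assay, 4-ethylphenyl in place of 3-ethylphenyl gives a 10-fold higher number from compound 3 to compound 4 (1.00 log units; beyond the scatter), so on the core of compound 3 this change reverses the direction it took on the core of compound 1: the same change on two cores in this assay, a 5.0-fold lower number (0.70 log units; beyond the scatter) from compound 1 to compound 2 and a 10-fold higher number (1.00 log units; beyond the scatter) from compound 3 to compound 4, 50-fold (1.70 log units) apart, beyond the scatter of two such steps The change of isopropyl to benzyl also fails to carry over, giving a 10-fold higher number from compound 2 to compound 4 (1.00 log units; beyond the scatter), against its earlier step: the same change on two cores in this assay, a 5.0-fold lower number (0.70 log units; beyond the scatter) from compound 1 to compound 3 and a 10-fold higher number (1.00 log units; beyond the scatter) from compound 2 to compound 4, 50-fold (1.70 log units) apart, beyond the scatter of two such steps The effects of the two changes therefore do not simply add up across these four compounds, but the numbers do not show why, nor whether this holds beyond them.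

On these data alone, it remains open whether a propyl chain in place of the ethyl group would follow the isopropyl core or the benzyl core. The same question stands for other groups in place of benzyl, such as a cyclohexylmethyl group.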